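The source may report more compounds than this note shows. Statements on the series, on what has been measured and on what is new or still open speak of the compounds shown alone.

Measured so far in an assay on CHO cells for antagonist activity at Orexin receptor type 2 (Homo sapiens), read by FLIPR, with a stated time of 5 min; on this read-out lower numbers stand for stronger inhibition and higher numbers for weaker inhibition:
Compound 1 `COc1ccc(CNC(=O)c2cc(-c3cncc(C)c3)ncc2-c2cncc(F)c2)nc1OC` gives 57 nM.
Compound 2 `COc1ccc(CNC(=O)c2sc(-c3cncc(C)c3)nc2-c2cccc(F)c2)nc1OC` gives 1060 nM.
Compound 3 `COc1ccc(CNC(=O)c2cc(-c3cncc(C)c3)ncc2N2CCC2)nc1OC` gives 83 nM.

Among these three numbers compound 3 sits second highest. Its nearest neighbour is compound 1, whose number is lower by only a 1.5-fold higher number from compound 1 to compound 3 (0.16 log units; within the scatter) in the other direction, so the two cannot be told apart. Compound 2 stands far off, with a number that is much higher than that of compound 3; compound 2 also carries a different core, so that gap cannot be tied to one group.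

The next compound, compound 4 `COc1ccc(CNC(=O)c2cc(-c3cncc(C)c3)ncc2-c2cnn(C)c2)nc1OC`, is derived from compound 3 by a single change: 1-methyl-1H-pyrazol-4-yl in place of azetidin-1-yl on an aromatic carbon. Going by the values given here, the one measured step that bears on this position is the move from compound 1 to compound 3, in which a six-membered aromatic ring gave way to azetidin-1-yl and the number changed by only a 1.5-fold higher number from compound 1 to compound 3 (0.16 log units; within the scatter), within the scatter. Going back from azetidin-1-yl to an aromatic ring, here a five-membered one, is therefore expected to change this assay by little, with a step of about a 1.4-fold lower number from compound 3 to compound 4 (0.14 log units; within the scatter), expected and not beyond the scatter. Compound 4 is thus estimated at 60 nM, expected to fall between 25 nM and 150 nM.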

Compound 4, half-maximal inhibitory concentration: 167 nM
For compound 4 the middle estimate is 2.8-fold (0.44 log units) below the measured one; measured number outside the range, above it.
By their numbers in this assay, from the lowest: compounds 1, 3 and 4 (each within the scatter of the next, the first and the last beyond it); then compound 2.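

In this assay this position, on an aromatic carbon of a six-membered aromatic ring with 1 nitrogen, now gives its first step beyond the scatter between single-place analogues: 1-methyl-1H-pyrazol-4-yl in place of 5-fluoropyridin-3-yl gives a 2.9-fold higher number from compound 1 to compound 4 (0.47 log units; beyond the scatter) and remains a modest change. Placing the same 1-methyl-1H-pyrazol-4-yl where azetidin-1-yl stood gives a 2.0-fold higher number from compound 3 to compound 4 (0.30 log units; within the scatter) and leaves compound 3 and compound 4 indistinguishable. An aromatic ring at this position therefore does not by itself guarantee a number matching that of compound 1, and the groups are not fully interchangeable, although compound 3 cannot be separated from either compound 1 or compound 4. Nothing available here accounts for the difference between these groups.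

The compounds shown leave open how an open-chain amine such as dimethylamino, or a methoxy group, would read at this position, and whether the methyl on the pyrazole ring matters to the number. They also leave open whether these same replacements would give similar steps on the core of compound 2.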